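Working notes on a weak sulfonamide series

The source may report more compounds than this note shows. Statements on the series, on what has been measured and on what is new or still open speak of the compounds shown alone.

Compound 1 `O=S(=O)(Nc1ccc2oc(-c3ccccc3)nc2c1)c1ccccc1O` gives 85000 nM in an assay on cells for inhibition of HSP60/HSP10 (Homo sapiens), with a stated time of 60 min (on this read-out higher numbers stand for weaker inhibition and lower numbers for stronger inhibition), the highest of the three numbers measured; compound 3 `O=S(=O)(Nc1ccc(-c2nc3cc(NS(=O)(=O)c4ccccc4O)ccc3o2)cc1)c1ccccc1O` gives 18000 nM and compound 2 `O=S(=O)(Nc1ccc2oc(-c3ccc(NS(=O)(=O)c4cccc5nonc45)cc3)nc2c1)c1ccc(Cl)s1` gives 13000 nM. Among the measured compounds shown here, the only single-point step, a 4.7-fold lower number from compound 1 to compound 3 (0.67 log units; beyond the scatter), puts ((2-hydroxyphenyl)sulfonyl)amino in place of hydrogen on an aromatic carbon and leaves the group on the sulfonyl sulfur unchanged. Compound 4 `COc1cccc(S(=O)(=O)Nc2ccc3oc(-c4ccccc4)nc3c2)c1` differs from compound 1 by 3-methoxyphenyl in place of 2-hydroxyphenyl on a sulfonyl sulfur. No measured step alters the group on the sulfonyl sulfur, so nothing shown bears directly on this change; the expectation is therefore a step of no change at the digits printed from compound 1 to compound 4 (within the scatter), not beyond the scatter, with a wide range. Compound 4 is estimated at 85000 nM, between 30000 nM and 250000 nM.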

Compound 4, half-maximal inhibitory concentration: > 100000 nM
Compound 4: a limit, no number; the forecaster's own chance of this, stated with the estimate: 30%; at least 1.1-fold (0.07 log units) between middle value and limit.
By their numbers in this assay, from the lowest: compounds 2 and 3 (each within the scatter of the next); then compound 1. At a limit, above all of these: compound 4.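

Among the compounds shown here, this is the first reading on the group on the sulfonyl sulfur: 3-methoxyphenyl in place of 2-hydroxyphenyl gives an at least 1.1-fold higher number from compound 1 to compound 4 (0.07 log units; that floor lies within the scatter), so the change shows no gain, and that floor does not separate it from no change. Compound 4 stands at a limit in this assay, not at a number: the limit of > 100000 nM in this assay, at which 1 of the 4 values shown sits.

The real size of the step stays unread. Also open, on these data alone, is whether the hydroxyl itself or its place on the ring counts, a question that 2-methoxyphenyl or 3-hydroxyphenyl on the sulfonyl sulfur would address.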